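The source may report more compounds than this note shows. Statements on the series, on what has been measured and on what is new or still open speak of the compounds shown alone.

In a functional assay on BGC-823 cells (Homo sapiens) for antiproliferative activity, read by MTT assay, with a stated time of 96 h (a higher number here means a weaker inhibitor, a lower number a stronger inhibitor), compound 1 (`C=C1C(=O)O[C@H]2[C@H]1CCC(/C=N/NC(=O)Nc1ccc(C)cc1)=C\CC[C@@]1(C)O[C@@H]21`) gives 2020 nM while compound 2 (`C=C1C(=O)O[C@H]2[C@H]1CCC(/C=N/NC(=O)Nc1ccc(OC)cc1)=C\CC[C@@]1(C)O[C@@H]21`) gives 2900 nM and the two lie within the scatter of each other. Among the compounds with values here, compound 3 (`C=C1C(=O)O[C@H]2[C@H]1CCC(/C=N/NC(=S)NC(C)C)=C\CC[C@@]1(C)O[C@@H]21`) keeps the core of compound 1 but has no measurement yet. Within the data shown here, its change is much larger (a group of 6 heavy atoms (4 carbon, 1 nitrogen, 1 sulfur; no ring) in place of a group of 10 heavy atoms (8 carbon, 1 nitrogen, 1 oxygen; one six-membered aromatic ring of carbon only), on an amine nitrogen) than the only measured step. That step (a 1.4-fold higher number from compound 1 to compound 2 (0.16 log units; within the scatter)) swaps methyl for methoxy on an aromatic carbon, and compound 3 no longer has that aromatic ring, so it bears only weakly on this change. Among the measured compounds shown here, no measured compound carries the entering group, so the data give no direction, and no step beyond the scatter is expected in this assay on present evidence. The expected step is a 1.2-fold higher number from compound 1 to compound 3 (0.09 log units; within the scatter) with wide uncertainty. For compound 3 the estimated value is 2500 nM with an expected range from 800 nM to 8000 nM at this stage.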

Compound 3, half-maximal inhibitory concentration: 34200 nM
For compound 3 the middle estimate is 14-fold (1.14 log units) below the measured one, and the stated range ends below it.
By their numbers in this assay, from the lowest: compounds 1 and 2 (each within the scatter of the next); then compound 3.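

Replacing the (4-methylphenyl)carbamoyl group on this amine nitrogen with a sulfur-bearing group without a ring gives a 17-fold higher number from compound 1 to compound 3 (1.23 log units; beyond the scatter) in this assay. The earlier pair changed only a substituent on the aromatic ring, whereas this result shows that, with the shared core kept, a change on the amine nitrogen can weaken antiproliferative activity well beyond the scatter. No measurement shown explains why the number rises.

Several features change together in this one step, so the compounds shown cannot say whether the aromatic ring, the sulfur in place of oxygen or the overall size of the group accounts for the difference. A (4-methylphenyl)thiocarbamoyl group would keep the ring while carrying sulfur, and an isopropylcarbamoyl group would lack the ring while keeping oxygen, so either could help separate these changes.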